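Iodine to Amino: Two Cores, One Swap

The source may report more compounds than this note shows. Statements on the series, on what has been measured and on what is new or still open speak of the compounds shown alone.

Of the compounds shown here, three have been tested in an ADME assay on L1210/0 cells (Mus musculus) for cytotoxicity, with a stated time of 48 h (a lower number here means a stronger inhibitor, a higher number a weaker inhibitor), and a fourth awaits measurement. Compound 1 `CC(=O)OC(C)Cn1cnc2c(Cl)nc(I)nc21` gives 13000 nM in this assay. Compound 3 `CC(=O)OC(C)Cn1cnc2c(Cl)nc(N)nc21` differs from it by amino in place of iodo on an aromatic carbon. For compound 3 this assay reports only a limit, > 200000 nM, rather than a number. The step is an at least 15-fold higher number from compound 1 to compound 3 (1.18 log units; beyond the scatter). The value of compound 3 sits at the limit of > 200000 nM in this assay, at which 1 of the 3 values shown sits.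

Compound 2 `Nc1nc2c(nc(I)n2COCCO)c(=O)[nH]1` rests on a different core; how the two cores differ is not broken down here. In this assay compound 2 gives 111000 nM, the highest of the two numbers shown, with compound 1 and its lower number nearest.

Compound 4 `Nc1nc2c(nc(N)n2COCCO)c(=O)[nH]1` is not yet measured. It differs from compound 2 by amino in place of iodo on an aromatic carbon. For the measured compounds named here, this is the same kind of change as the one from compound 1 to compound 3, but not the same: in compound 3 the amino sits on a six-membered aromatic ring with 2 nitrogen, meta to a chloro group, meta to a fused ring and para to a fused ring, whereas in compound 4 it sits on a five-membered aromatic ring with 2 nitrogen, next to the ring atom that bears a (2-hydroxyethoxy)methyl group. Because the earlier swap gave an at least 15-fold higher number from compound 1 to compound 3 (1.18 log units; beyond the scatter), the step in this assay is expected to be a 5.4-fold higher number from compound 2 to compound 4 (0.73 log units; beyond the scatter). Compound 4 is therefore estimated at 600000 nM, between 150000 nM and 3000000 nM, and this assay will most likely report only a limit for it.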

Compound 4, half-maximal inhibitory concentration: > 200000 nM
Compound 4: only a limit was reported; the forecaster's own chance of this, stated with the estimate: 80%; the middle value is on the limit's open side.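

In this assay, amino in place of iodo on the core of compound 2 gives an at least 1.8-fold higher number from compound 2 to compound 4 (0.25 log units; that floor lies within the scatter), which is only a floor for the step, and a floor that cannot by itself be told apart from the ordinary scatter of repeated measurements. Compound 3 and compound 4, the two amino compounds, both end at a limit of the assay and not at a true number: the limit of > 200000 nM in this assay, at which 2 of the 4 values shown sit. On both cores, then, the amino compound has no lower number than its iodo partner, but this does not show that the swap carries over with the same size from one core to the other: the same change on two cores in this assay, an at least 15-fold higher number (1.18 log units; beyond the scatter) from compound 1 to compound 3 and an at least 1.8-fold higher number (0.25 log units; that floor lies within the scatter) from compound 2 to compound 4; the limit leaves it open whether they differ.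

Going by these compounds, what remains open is the true size of the swap on each core, and whether the two cores would respond alike if both amino compounds gave real numbers. The compounds shown also leave open how other groups on that same aromatic carbon would read in this assay, such as bromo or a methylamine in place of iodo, and whether a longer chain in place of the (2-hydroxyethoxy)methyl group would alter the outcome of the swap.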